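Dipentylamino for dibutylamino: compound 3 to compound 4

A few compounds are considered here, and "the series" means these few. Any claim that something is new, unique, unknown or untested is made for them only; others in the source may bear on it.

Measured so far in a functional assay on PC-3 cells (Homo sapiens) for antiproliferative activity, read by WST assay, with a stated time of 3 days (on this read-out higher numbers stand for weaker inhibition and lower numbers for stronger inhibition), as follows
- compound 1 `CCCCCCOc1c(-c2cc(OC)c(OC)c(OC)c2)oc2ccccc2c1=O` gives 29200 nM
- compound 2 `CCCN(CCC)CCCCCOc1c(-c2cc(OC)c(OC)c(OC)c2)oc2ccccc2c1=O` gives 2600 nM
- compound 3 `CCCCN(CCCC)CCCOc1c(-c2cc(OC)c(OC)c(OC)c2)oc2ccccc2c1=O` gives 7100 nM

Compound 3 at 7100 nM holds the second highest of the three numbers. Compound 4 `CCCCCN(CCCCC)CCCOc1c(-c2cc(OC)c(OC)c(OC)c2)oc2ccccc2c1=O` differs from compound 3 by dipentylamino in place of dibutylamino on a saturated chain carbon, three bonds along the chain from an oxygen on an aromatic ring with dipentylamino in place of dibutylamino. Going by the values given here, no measured step isolates this change. The closest evidence is a 4.1-fold lower number from compound 1 to compound 3 (0.61 log units; beyond the scatter) and an 11-fold lower number from compound 1 to compound 2 (1.05 log units; beyond the scatter) but both replace a plain chain end with an amino group. The step of a 2.7-fold higher number from compound 2 to compound 3 (0.44 log units; beyond the scatter) alters chain and amino group together. Only a small step is therefore expected in this assay with no firm direction. The expected step is a 1.2-fold lower number from compound 3 to compound 4 (0.07 log units; within the scatter) and so none beyond the scatter. Compound 4 is estimated at 6000 nM with 2500 nM to 15000 nM as the expected range.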

Compound 4, half-maximal inhibitory concentration: 5800 nM
Estimate against measurement, compound 4: 1.0-fold (0.01 log units) above; the range from low to high includes it.
By their numbers in this assay, from the lowest: compound 2; then compounds 4 and 3 (each within the scatter of the next); then compound 1.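

Within this assay, dipentylamino in place of dibutylamino on the saturated chain carbon, three bonds along the chain from an oxygen on an aromatic ring, gives no change beyond the scatter (a 1.2-fold lower number from compound 3 to compound 4 (0.09 log units; within the scatter)). The amino-bearing chain with dipentylamino still separates from the plain chain end (a 5.0-fold lower number from compound 1 to compound 4 (0.70 log units; beyond the scatter)) but does not match the dipropylamino compound (a 2.2-fold higher number from compound 2 to compound 4 (0.35 log units; beyond the scatter)). No evidence on the cause of these steps is available.

The compounds shown leave open whether the gap to compound 2 belongs to the chain or to the amino group. As far as these compounds go, a smaller dimethylamino group or a ring amine such as piperidine at this chain end also remains untested here.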